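The source may report more compounds than this note shows. Statements on the series, on what has been measured and on what is new or still open speak of the compounds shown alone.

Measured so far:
Compound 1 `COc1cc(/C=C/C(=O)/C=C(/C=C/c2ccc(O)c(OC)c2)NCCCO)ccc1O` gives 88500 nM
Compound 2 `COCCNC(=C\C(=O)/C=C/c1ccc(O)cc1)/C=C/c1ccc(O)cc1` gives 34900 nM

Both values come from a toxicity assay on CHO-K1 cells (Cricetulus griseus) for cytotoxicity, read by MTT assay, with a stated time of 48 h (on this read-out lower numbers stand for stronger inhibition and higher numbers for weaker inhibition), and the gap between them lies beyond the usual scatter. Compound 2 at 34900 nM holds the lower number of the two, with compound 1 as its nearest neighbour. Among the compounds with values here, no step between measured compounds that differ in one place is available yet.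

Compound 3 `COCCCNC(=C\C(=O)/C=C/c1ccc(O)cc1)/C=C/c1ccc(O)cc1` is still unmeasured in this assay and departs from compound 2 at one place (methoxymethyl in place of methoxy on a saturated chain carbon, two bonds along the chain from an amine nitrogen) with methoxymethyl in place of methoxy on a saturated chain carbon, two bonds along the chain from an amine nitrogen. The same difference reads as (2-methoxyethyl)amino to (3-methoxypropyl)amino. Within the data shown here, with no measured step to lean on, no shift beyond the scatter is expected, and no direction is favoured. The estimated 1.0-fold lower number from compound 2 to compound 3 (0.01 log units; within the scatter) stays within that scatter. For compound 3 the expected value is 34000 nM with an estimated range from 16000 nM to 75000 nM in this read-out.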

Compound 3, half-maximal inhibitory concentration: 44900 nM
Estimate against measurement, compound 3: 1.3-fold (0.12 log units) below; measured number inside the range.
By their numbers in this assay, from the lowest: compounds 2, 3 and 1 (each within the scatter of the next, the first and the last beyond it).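

In this assay, the series now has its first comparison of compounds that differ in one place, and it gives a 1.3-fold higher number from compound 2 to compound 3 (0.11 log units; within the scatter). On this read-out, (2-methoxyethyl)amino and (3-methoxypropyl)amino cannot be told apart, so methoxymethyl in place of methoxy on a saturated chain carbon, two bonds along the chain from an amine nitrogen, shows no effect that can be resolved from the scatter in this pair, and a single pair sets no trend for the position. No data that could explain this result are available.

On these data alone, it remains open whether a longer chain such as 4-methoxybutyl, or a hydroxyl group, an amine or a carboxylic acid in place of the methoxy, would move the number beyond the scatter. Compound 1 differs from compound 2 and from compound 3 in more than one place, so it cannot show what its own chain contributes apart from the other differences, and the effect of each of those differences remains unresolved.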